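One Change Made Twice in a Kinase Inhibitor Series

The source may hold more compounds than are shown below. What is called first, only, known or untested is meant among the compounds shown, and "the series" means these compounds.

Measured compounds:
Compound 1, `Cc1nn(C2COC2)cc1Nc1nc(N)c2c(C#N)c(N3CCC[C@H]3C)n(C)c2n1`: 25 nM
Compound 2, `Cc1nn(CC(C)(C)O)cc1Nc1nc(N)c2c(C#N)c(N3CCC[C@H]3C)n(C)c2n1`: 42 nM
Compound 3, `Cc1c(Nc2nc(N)c3c(C#N)c(N4CCC[C@H]4C)n(C)c3n2)cnn1C1COC1`: 37 nM

All three were tested in an assay on isolated protein for inhibition of Leucine-rich repeat serine/threonine-protein kinase 2 variant G2019S (Homo sapiens), read by TR-FRET and LanthaScreen, with stated times of 50 min and 30 min, in the presence of a further agent that is not named here; a higher number here means a weaker inhibitor, a lower number a stronger inhibitor. Compound 1 and compound 2 differ in one place: 2-hydroxy-2-methylpropyl in place of oxetan-3-yl on an aromatic nitrogen. That change gave a 1.7-fold higher number from compound 1 to compound 2 (0.23 log units; within the scatter). Compound 1 and compound 3 share the same atoms joined differently: 5-methyl-1-(oxetan-3-yl)-1H-pyrazol-4-yl in place of 3-methyl-1-(oxetan-3-yl)-1H-pyrazol-4-yl on a nitrogen on an aromatic ring, with a 1.5-fold higher number from compound 1 to compound 3 (0.17 log units; within the scatter).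

Compound 4, `Cc1c(Nc2nc(N)c3c(C#N)c(N4CCC[C@H]4C)n(C)c3n2)cnn1CC(C)(C)O`, has not yet been measured in this assay. It differs from compound 3 as follows: 2-hydroxy-2-methylpropyl in place of oxetan-3-yl on an aromatic nitrogen. Within the data shown here, this is the same kind of change as the one from compound 1 to compound 2, but not the same, since the surroundings differ: in compound 1 the replaced group sits two ring bonds from the ring atom that bears a methyl group, whereas in compound 3 it sits next to the ring atom that bears a methyl group.

Because the earlier step of a 1.7-fold higher number from compound 1 to compound 2 (0.23 log units; within the scatter) stayed small, the step from compound 3 to compound 4 is expected to be of similar size, estimated as a 1.7-fold higher number from compound 3 to compound 4 (0.23 log units; within the scatter). On that basis compound 4 is estimated to give about 63 nM in this assay, with a likely range from 30 nM to 130 nM.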

Compound 4, half-maximal inhibitory concentration: 35 nM
Compound 4: the middle estimate sits 1.8-fold (0.26 log units) above what was measured; low and high end bracket the measured number.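

In this assay, putting 2-hydroxy-2-methylpropyl in place of oxetan-3-yl on the aromatic nitrogen gave a 1.1-fold lower number from compound 3 to compound 4 (0.02 log units; within the scatter), so on the core of compound 3 the swap left the reading within the scatter. Set beside the earlier case, the two results do not differ beyond what repeated measurements would be expected to show: the same change on two cores in this assay, a 1.7-fold higher number (0.23 log units; within the scatter) from compound 1 to compound 2 and a 1.1-fold lower number (0.02 log units; within the scatter) from compound 3 to compound 4, 1.8-fold (0.25 log units) apart, within the scatter of two such steps. Across these two pairs, which carry the ring methyl group in different places, the swap was tolerated both times, but two pairs in one assay do not establish a rule for other cores, and steps this small cannot show whether the change truly acts the same way on both cores or differs slightly.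

The compounds shown leave open how other groups on that aromatic nitrogen, such as a plain methyl, an amine such as piperidin-4-yl or a longer chain ending in a carboxylic acid, would read in this assay. They also leave open whether the swap from oxetan-3-yl to 2-hydroxy-2-methylpropyl would stay this small on a core carrying an amide in place of the nitrile.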